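Removing a methyl from an aminonucleoside and the expected outcome

A few compounds are considered here, and "the series" means these few. Any claim that something is new, unique, unknown or untested is made for them only; others in the source may bear on it.

Measured compounds:
Compound 1, `OC[C@H]1O[C@@H](n2cnc3c(NCc4ccccc4)nccc32)C[C@@H]1O`: 8%
Compound 2, `CN(C)c1nccc2c1ncn2C1O[C@H](CO)[C@@H](O)[C@H]1O`: 10%

Of the compounds shown here, two have been measured in a functional assay on EL4 cells (Mus musculus) for inhibition, tested at 100 uM; on this read-out lower numbers stand for less inhibition and higher numbers for more inhibition at the one concentration tested (going by the name of the read-out). Compound 1 `OC[C@H]1O[C@@H](n2cnc3c(NCc4ccccc4)nccc32)C[C@@H]1O` gives 8% in this assay. Compound 2 `CN(C)c1nccc2c1ncn2C1O[C@H](CO)[C@@H](O)[C@H]1O` gives 10% in this assay. The difference between the two numbers lies within the scatter of repeated measurements, so the two numbers are level at a low level of inhibition in this assay, and neither can be called the higher.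

Compound 3 `CNc1nccc2c1ncn2C1O[C@H](CO)[C@@H](O)[C@H]1O` has not yet been measured. It differs from compound 2 in one place: hydrogen in place of methyl on a nitrogen on an aromatic ring. Within the data shown here, nothing among the measured compounds shows what this kind of change does in this assay. Among the measured compounds shown here, no pair of measured compounds differs by a single change. Since compound 2 gives 10% and compound 1 gives 8%, both low, the expectation is that compound 3 will also show little inhibition, and the step expected from the measured value is no change at the digits printed from compound 2 to compound 3 (within the scatter), that is, none beyond the scatter. Compound 3 is expected to give about 10%, between 0% and 25%.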

Compound 3, a percentage reported as inhibition, at one concentration (the size of the read-out at that concentration, not a potency): 11%
Compound 3: middle estimate off by 1 percentage points, on the low side, within the range that was stated.
By their numbers in this assay, from the lowest: compounds 1, 2 and 3 (each within the scatter of the next).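

In this assay, the dimethylamino to methylamino change gives a number 1 percentage points higher from compound 2 to compound 3 (within the scatter). Among these compounds, this is the first pair that differs in one place, and it shows that hydrogen can stand in place of methyl on this nitrogen on an aromatic ring with the read-out staying level at a low level of inhibition. Nothing measured here bears on why the two compounds read level, and with both this low at one concentration, the pair says little about what this methyl would do in a compound with more inhibition.

The compounds shown leave open whether the primary amine, with the remaining methyl also replaced by hydrogen, would stay at this low level, or whether a longer chain such as propyl on the same nitrogen would lift the number clear of it. They also leave open whether a carboxylic acid at the end of such a chain would change the reading in this assay, so the flat step describes only the loss of one methyl at this position.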